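Estimating Cytotoxicity for a Chloro Analogue on a Piperidine Core

A few compounds are considered here, and "the series" means these few. Any claim that something is new, unique, unknown or untested is made for them only; others in the source may bear on it.

Compound 1 `CCN(CC)Cc1ccc2nc(NC(=O)N/N=C/c3cn(Cc4ccccc4)c4ccccc34)sc2c1` is the starting point; in a functional assay on NCI-H460 cells (Homo sapiens) for cytotoxicity, read by MTT assay, with a stated time of 72 h (a lower number here means a stronger inhibitor, a higher number a weaker inhibitor), compound 1 gives 450 nM. Compound 2 `CCN(CC)Cc1ccc2nc(NC(=O)N/N=C/c3cn(Cc4ccccc4Cl)c4ccccc34)sc2c1` carries the change (chloro in place of hydrogen on an aromatic carbon), and in this assay compound 2 gives 980 nM, a step of a 2.2-fold higher number from compound 1 to compound 2 (0.34 log units; beyond the scatter). Compound 3 `CC1CCN(Cc2ccc3nc(NC(=O)N/N=C/c4cn(Cc5ccccc5)c5ccccc45)sc3c2)CC1` has a different core, where (4-methylpiperidin-1-yl in place of diethylamino on a saturated chain carbon bound to an aromatic carbon); in this assay compound 3 gives 1910 nM, and the step is a 4.2-fold higher number from compound 1 to compound 3 (0.63 log units; beyond the scatter).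

Compound 4 `CC1CCN(Cc2ccc3nc(NC(=O)N/N=C/c4cn(Cc5ccc(Cl)cc5)c5ccccc45)sc3c2)CC1` awaits measurement. It differs from compound 3 by chloro in place of hydrogen on an aromatic carbon. This is the same kind of change as from compound 1 to compound 2, though not the same: there the chloro sits ortho to a large group, here para to a large group, and the cores differ as described. The earlier step of a 2.2-fold higher number from compound 1 to compound 2 (0.34 log units; beyond the scatter) is the only measure of this kind of change here. A similarly modest weakening is expected, a step of a 1.6-fold higher number from compound 3 to compound 4 (0.20 log units; within the scatter). Compound 4 is therefore estimated at 3000 nM, likely between 1200 nM and 7500 nM.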

Compound 4, half-maximal inhibitory concentration: 400 nM
Estimate against measurement, compound 4: 7.5-fold (0.88 log units) above, and the stated range ends above it.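

In this assay, adding the chloro gave a 4.8-fold lower number from compound 3 to compound 4 (0.68 log units; beyond the scatter), so this step runs in the opposite direction to the one from the core of compound 1 to compound 2. One change therefore cannot be assumed to carry the same result from one core to the other in this series: the same change on two cores in this assay, a 2.2-fold higher number (0.34 log units; beyond the scatter) from compound 1 to compound 2 and a 4.8-fold lower number (0.68 log units; beyond the scatter) from compound 3 to compound 4, 10-fold (1.02 log units) apart, beyond the scatter of two such steps. This does not show what lies behind the reversal, as the two pairs differ both in the core and in where the chloro stands, with 4-chlorobenzyl in compound 4 and the chloro elsewhere on that ring in compound 2.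

Open, from the compounds shown here alone, is how 4-chlorobenzyl would behave on the core of compound 1, which would help separate those two differences. Also open, going by these compounds, is how a fluoro or a methoxy group would read in the same place on the ring.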